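A few compounds are considered here, and "the series" means these few. Any claim that something is new, unique, unknown or untested is made for them only; others in the source may bear on it.

Measured compounds:
compound 1 `COc1ccc(F)cc1CNCCCNc1ccnc2cc(Cc3ccc(C#N)cc3)ccc12` gives 6050 nM
compound 2 `COc1ccc(F)cc1CNCCCNc1ccnc2cc(Cc3ccc(F)cc3Cl)ccc12` gives 2460 nM
compound 3 `COc1ccc(F)cc1CNCCCNc1ccnc2cc(Cc3ccccc3)ccc12` gives 7990 nM

In an ADME assay on HepG2 cells (Homo sapiens) for cytotoxicity, read by luminescence, CellTiter-Glo and ATP content, with a stated time of 72 h (a higher number here means that more compound is needed for the effect, a lower number that less compound is needed), compound 3 holds the highest of the three numbers. The step of a 1.3-fold higher number from compound 1 to compound 3 (0.12 log units; within the scatter) stays within the scatter, whereas a 3.2-fold higher number from compound 2 to compound 3 (0.51 log units; beyond the scatter) lies beyond it. Compound 4 `COc1ccc(F)cc1CNCCCNc1ccnc2cc(Cc3cc(C)cc(C)c3)ccc12` differs from compound 3 only in the benzyl group: 3,5-dimethylphenyl in place of phenyl on a saturated chain carbon bound to an aromatic carbon. For the measured compounds named here, the steps that bear on this change all sit on the same aromatic ring: a 2.5-fold lower number from compound 1 to compound 2 (0.39 log units; beyond the scatter), a 1.3-fold higher number from compound 1 to compound 3 (0.12 log units; within the scatter) and a 3.2-fold higher number from compound 2 to compound 3 (0.51 log units; beyond the scatter). All are modest, and only the substituted ring of compound 2 shifted the number beyond the scatter. A step of at most that size is therefore expected in this assay, if anything toward a lower number: a 1.5-fold lower number from compound 3 to compound 4 (0.16 log units; within the scatter). Compound 4 is expected to give 5500 nM, within a range of 2200 nM to 13000 nM.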

Compound 4, half-maximal effective concentration: 940 nM
For compound 4 the middle estimate is 5.9-fold (0.77 log units) above the measured one; measured number below the stated range.
By their numbers in this assay, from the lowest: compound 4; then compound 2; then compounds 1 and 3 (each within the scatter of the next).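

In this assay, for the compounds shown here, this position proves more responsive than the earlier compounds suggested: 3,5-dimethylphenyl in place of phenyl gives the largest step seen here (an 8.5-fold lower number from compound 3 to compound 4 (0.93 log units; beyond the scatter)). The same group also goes beyond the 2-chloro-4-fluorophenyl (a 2.6-fold lower number from compound 2 to compound 4 (0.42 log units; beyond the scatter)) and 4-cyanophenyl (a 6.4-fold lower number from compound 1 to compound 4 (0.81 log units; beyond the scatter)) rings, leaving compound 4 with the lowest number of the four. Nothing available here accounts for this shift. Going by these compounds, it remains open whether 3-methylphenyl alone would give a similar step, and how a carboxylic acid or an amine on this ring would read.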